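Swapping a Chlorobenzyl Ether for a Cyanobenzyl Ether

This account rests on a few compounds, and the source may have more. Where it says the series, first, only, none or still open, it means among the compounds named here.

In an assay on HEK293 cells for inhibition of transient receptor potential cation channel subfamily M member 8 (Homo sapiens), read by FLIPR and calcium flux (a higher number here means a weaker inhibitor, a lower number a stronger inhibitor), compound 3 `CCN(C(=O)c1ccccc1OCc1cccc(Cl)c1)C1CCCC(N)C1` gives 96.6 nM. Within the data shown here, this is the lowest of the two numbers measured so far; the nearest is compound 2 `N[C@H]1CCC[C@@H](N(CC2CC2)C(=O)c2ccccc2OCc2ccccc2)C1`, which gives 665 nM, a gap beyond the usual scatter of repeated measurements. Compound 1 `CCN(C(=O)c1ccccc1OCc1ccccc1)C1CCNCC1` reaches only the limit of the assay, > 5000 nM, and so yields no number; this is the limit of > 5000 nM in this assay, at which 1 of the 3 values shown sits. Compound 4 `CCN(C(=O)c1ccccc1OCc1ccccc1C#N)C1CCCC(N)C1` differs from compound 3 in a single place: 2-cyanophenyl in place of 3-chlorophenyl on a saturated chain carbon bound to an oxygen on an aromatic ring. Among the measured compounds shown here, the group that leaves carries a chlorine and the group that enters carries a nitrile, so the change alters both the kind of substituent and where it sits on the outer ring, and none of the measured compounds shows what either alteration does to the read-out. For the measured compounds named here, with no measured step to lean on, the expectation for the step of a 2.6-fold higher number from compound 3 to compound 4 (0.41 log units; beyond the scatter) is a modest weakening, of a size that may not clear the scatter. The estimate for compound 4 in this assay is 250 nM, within a range from 60 nM to 1000 nM.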

Compound 4, antagonist equilibrium constant: 1250 nM
Estimate against measurement, compound 4: 5.0-fold (0.70 log units) below; the measured number lies above the stated range.
By their numbers in this assay, from the lowest: compound 3; then compounds 2 and 4 (each within the scatter of the next). At a limit, above all of these: compound 1.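

In this assay, the outer ring of the benzyl ether proves to be a sensitive place: with the rest of the molecule unchanged, exchanging 3-chlorobenzyl for 2-cyanobenzyl gives a large step (a 13-fold higher number from compound 3 to compound 4 (1.11 log units; beyond the scatter)). Among these compounds, this is the first direct reading of a change at this place, since no earlier pair of compounds differed in only one spot, and it shows that the choice of group on this ring can by itself move the read-out well beyond the scatter. The entering group carries a hydrogen-bond acceptor that the leaving group lacks, yet the step runs toward weaker inhibition, and nothing measured here explains why.

The step changes two things at once, the kind of substituent and where it sits on the ring, so it cannot show which of them matters: a 2-chlorobenzyl or a 3-cyanobenzyl group on the same core would separate the two. On these data alone, whether other groups on this ring, such as a methoxy group or a fluorine, would match or improve on the 3-chlorobenzyl of compound 3 also remains open.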